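Aryl variation on a shared pyridine core: glucagon receptor binding

The source may report more compounds than this note shows. Statements on the series, on what has been measured and on what is new or still open speak of the compounds shown alone.

Measured so far:
- compound 1, `CCCCCc1c(C(C)C)nc(C(C)C)c(CO)c1-c1ccc(F)cc1F`, 11000 nM in an assay on CHO cells for inhibition of Glucagon receptor (Homo sapiens); on this read-out higher numbers stand for weaker inhibition and lower numbers for stronger inhibition
- compound 2, `CCCCCc1c(C(C)C)nc(C(C)C)c(CO)c1-c1ccc(F)c(CO)c1`, 19000 nM in this assay

Among the compounds with values here, compound 2 gives the higher of the two numbers in this assay, with compound 1 as its only neighbour; the step of a 1.7-fold higher number from compound 1 to compound 2 (0.24 log units; within the scatter) lies within the scatter, so the two compounds cannot be ordered on these data.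

Compound 3, `CCCCCc1c(C(C)C)nc(C(C)C)c(CO)c1-c1ccccc1N`, has not yet been measured. It differs from compound 2 in one place: 2-aminophenyl in place of 4-fluoro-3-(hydroxymethyl)phenyl on an aromatic carbon.

Within the data shown here, only one measured step is available, and it concerns the same aromatic ring on the shared core: from compound 1 to compound 2 the aryl group changed and the number moved a 1.7-fold higher number from compound 1 to compound 2 (0.24 log units; within the scatter), within the scatter. Nothing measured addresses an aminophenyl group specifically. On this basis the change from compound 2 to compound 3 is expected to give a step of about a 1.1-fold lower number from compound 2 to compound 3 (0.05 log units; within the scatter), that is, no clear movement beyond the scatter in this assay. Compound 3 is therefore estimated at 17000 nM, with a plausible range from 5000 nM to 60000 nM.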

Compound 3, half-maximal inhibitory concentration: 2300 nM
For compound 3 the middle estimate is 7.4-fold (0.87 log units) above the measured one; measured number outside the range, below it.
By their numbers in this assay, from the lowest: compound 3; then compounds 1 and 2 (each within the scatter of the next).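

At the aromatic carbon opposite the ring nitrogen, the choice of aryl group can move the number in this assay beyond the scatter: 2-aminophenyl in place of 4-fluoro-3-(hydroxymethyl)phenyl gives (an 8.3-fold lower number from compound 2 to compound 3 (0.92 log units; beyond the scatter)), and 2-aminophenyl in place of 2,4-difluorophenyl gives (a 4.8-fold lower number from compound 1 to compound 3 (0.68 log units; beyond the scatter)). Compound 3 thus separates from both earlier compounds, which could not be ordered against each other, and it is the lowest of the three numbers, reached with a group of fewer heavy atoms than the 4-fluoro-3-(hydroxymethyl)phenyl group it replaces, although nothing ties the step to that count. No data bearing on the reason for this step are available.

From the compounds shown here alone, it remains open whether the lower number belongs to the amine itself or to the absence of the other ring substituents; a plain phenyl group, a 2-hydroxyphenyl group or a 3-aminophenyl group would help separate these. The pentyl and hydroxymethyl groups are the same in all three compounds, so it is also unsettled whether the step would hold with a shorter chain or a carboxylic acid in those places.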